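Swapping Methoxy for Trifluoromethyl in a Well-Tolerated Set

The compounds below may be only part of what the source reports. "The series", "measured", "known", "first", "only" and "open" are said of these compounds alone.

In an ADME assay on MDBK cells (Bos taurus) for cytotoxicity (a higher number here means that more compound is tolerated, a lower number that less compound is tolerated), compound 2 (`COc1ccc(Cn2ccc3nc(-c4ccccc4)nc-3c2)cc1`) gives > 100000 nM as its reading, and that is a limit of the assay, not a number. Compound 1 (`COc1ccccc1Cn1ccc2nc(-c3ccccc3)nc-2c1`) gives > 100000 nM as its reading, again a limit. Compound 3 (`Clc1ccccc1Cn1ccc2nc(-c3ccccc3)nc-2c1`) gives > 100000 nM and this too is a limit. The whole picture so far is the limit of > 100000 nM in this assay, at which 3 of the 3 values shown sit, and no measured number is available yet.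

Compound 4 (`FC(F)(F)c1ccc(Cn2ccc3nc(-c4ccccc4)nc-3c2)cc1`) has not been measured. It carries trifluoromethyl in place of methoxy on an aromatic carbon, a change counted as trifluoromethyl in place of methoxy on an aromatic carbon and set para to a large group. The nearest measured swap is a step that the two limits leave unreadable from compound 1 to compound 3 and it also replaces methoxy. Two further steps bear on the question more loosely, namely a step that the two limits leave unreadable from compound 1 to compound 2 and a step that the two limits leave unreadable from compound 2 to compound 3 as changes to the same substituted phenyl group. None of the three has a size that can be read, yet none of these changes brought a reading away from the limit. The step expected in this assay is a number no higher from compound 2 to compound 4 (the limit leaves the size open) and it is estimated to stay within the usual scatter, with no direction favoured. In this assay the expected value for compound 4 is 100000 nM (estimated range 40000 nM to 200000 nM).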

Compound 4, half-maximal cytotoxic concentration: 84000 nM
Estimate against measurement, compound 4: 1.2-fold (0.08 log units) above, and the stated range covers the measured number.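

In this assay, for the compounds shown here, compound 4 gives 84000 nM, the first reading in this set that is a real number rather than a limit, so trifluoromethyl on this aromatic carbon, para to a large group, brings the series within the range the assay can measure. Compound 2 has only a limit to compare with, so the change can be stated only as an at least 1.1-fold lower number from compound 2 to compound 4 (0.07 log units; that floor lies within the scatter), which means that the swap from methoxy to trifluoromethyl shows no tolerance difference that clearly exceeds ordinary variation, although a larger true step is not ruled out. The earlier steps still cannot be read, and most of the set remains at the ceiling: the limit of > 100000 nM in this assay, at which 3 of the 4 values shown sit.

The compounds shown leave open how large the step from methoxy to trifluoromethyl really is, since only one side of it is a number. They also leave open whether an amine or a carboxylic acid on the same aromatic carbon would give a measurable reading or stay at the limit, and whether trifluoromethyl would give a number at other places on this phenyl group.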